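Changing the aryl group on the carbonyl of compound 3

A few compounds are considered here, and "the series" means these few. Any claim that something is new, unique, unknown or untested is made for them only; others in the source may bear on it.

In a functional assay on MDA-MB-231 cells (Homo sapiens) for antiproliferative activity, with a stated time of 4 days (on this read-out lower numbers stand for stronger inhibition and higher numbers for weaker inhibition), compound 1 (`CCCCc1ccc2[nH]c(-c3ccc(OC)cc3)c(/C=N/NC(=O)c3ccc(F)cc3)c2c1`) gives 19 nM, compound 2 (`CCCCc1ccc2[nH]c(-c3ccc(OC)cc3)c(/C=N/NC(=O)c3ccc(OC)cc3)c2c1`) gives 61 nM, and compound 3 (`CCCCc1ccc2[nH]c(-c3ccc(OC)cc3)c(/C=N/NC(=O)c3ccccc3OC)c2c1`) gives 21 nM. Compound 3 thus sits with compound 1, as a 1.1-fold higher number from compound 1 to compound 3 (0.04 log units; within the scatter) shows, and apart from compound 2, as a 2.9-fold lower number from compound 2 to compound 3 (0.46 log units; beyond the scatter) shows. Compound 4 (`CCCCc1ccc2[nH]c(-c3ccc(OC)cc3)c(/C=N/NC(=O)c3ccc([N+](=O)[O-])cc3)c2c1`) carries one change from compound 3: 4-nitrophenyl in place of 2-methoxyphenyl on a carbonyl carbon. The nearest evidence is the same aryl position, where a 3.2-fold higher number from compound 1 to compound 2 (0.51 log units; beyond the scatter) is the other modest move seen. Within the data shown here, no nitro-bearing compound has been measured, so the direction is uncertain. The expected change is small, a 1.4-fold higher number from compound 3 to compound 4 (0.15 log units; within the scatter), leaning slightly towards a higher number. Compound 4 is estimated at 30 nM, with an expected range of 10 nM to 90 nM.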

Compound 4, half-maximal inhibitory concentration: 115 nM
Beside the measured number, compound 4's estimate is 3.8-fold (0.58 log units) below it; the measured number lies above the stated range.
By their numbers in this assay, from the lowest: compounds 1 and 3 (each within the scatter of the next); then compounds 2 and 4 (each within the scatter of the next).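

In this assay the carbonyl aryl group gives a second way to leave the level of compound 1 and compound 3: 4-nitrophenyl brings a 5.5-fold higher number from compound 3 to compound 4 (0.74 log units; beyond the scatter) and nitro in place of fluoro brings a 6.1-fold higher number from compound 1 to compound 4 (0.78 log units; beyond the scatter) on the same ring. Nitro and methoxy at that ring place cannot be told apart, with a 1.9-fold higher number from compound 2 to compound 4 (0.28 log units; within the scatter) as their step. No available evidence explains these shifts. As far as these compounds go, what an amine or a carboxylic acid at that ring place would give stays open, as does the effect of a 2-fluorophenyl group on the carbonyl carbon.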